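The source may hold more compounds than are shown below. What is called first, only, known or untested is meant among the compounds shown, and "the series" means these compounds.

Measured so far:
- compound 1 `CCCCCCc1cn([C@H]2C[C@H](O)[C@@H](CO)O2)c(=O)[nH]c1=O`, which in a functional assay on L1210 cells (Mus musculus) (a higher number here means a weaker inhibitor, a lower number a stronger inhibitor), gives 172 ug/mL
- compound 2 `CCCc1cn([C@H]2C[C@@H]3OP(=O)(O)OC[C@H]3O2)c(=O)[nH]c1=O`, for which this assay reports only a limit, > 500 ug/mL
- compound 3 `CCCCCc1cn([C@H]2C[C@@H]3OP(=O)(O)OC[C@H]3O2)c(=O)[nH]c1=O`, for which this assay likewise reports only a limit, > 500 ug/mL

Among the compounds with values here, compound 1 is thus the only compound with a number in this assay; the other two sit at the limit of > 500 ug/mL in this assay, at which 2 of the 3 values shown sit. Within the data shown here, the one measured step, a step that the two limits leave unreadable from compound 2 to compound 3, cannot be read in size for that reason. Compound 4 `CCCCCc1cn([C@H]2C[C@H](O)[C@@H](CO)O2)c(=O)[nH]c1=O` differs from compound 1 by hydrogen in place of methyl on a saturated chain carbon, five bonds along the chain from an aromatic carbon. No readable measured step bears on this shortening of the chain, and the step from compound 2 to compound 3 lengthens a chain instead. Compound 4 is therefore expected to stay near compound 1, a step of a 1.3-fold higher number from compound 1 to compound 4 (0.13 log units; within the scatter), with an estimate of 230 ug/mL, ranging from 90 ug/mL to 600 ug/mL.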

Compound 4, concentration for 50% inhibition: 476 ug/mL
Estimate against measurement, compound 4: 2.1-fold (0.32 log units) below, and the stated range covers the measured number.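

The change from methyl to hydrogen on a saturated chain carbon, five bonds along the chain from an aromatic carbon, now has a readable size in this assay, with a 2.8-fold higher number from compound 1 to compound 4 (0.44 log units; beyond the scatter). Within the data shown here, at this position, the compound with the shorter chain is the weaker inhibitor of the pair, which the earlier compounds could not show.

From the compounds shown here alone, this one pair sets no trend, and the effect of a longer chain, or of an amine or a carboxylic acid on this chain, stays open. A still shorter chain might yield no number: the limit of > 500 ug/mL in this assay, at which 2 of the 4 values shown sit.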